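This account rests on a few compounds, and the source may have more. Where it says the series, first, only, none or still open, it means among the compounds named here.

Working notes on the series. Of the compounds shown here, two of the shared core have been measured in a functional assay on the whole organism with Mus musculus as the target; a higher number here means that more compound is needed for the effect, a lower number that less compound is needed. Compound 1 `O=c1oc2cccnc2n1CN1CCN(c2cccc(C(F)(F)F)c2)CC1` gives 3.6 mg/kg in this assay. Compound 2 `O=c1oc2cccnc2n1CCN1CCN(c2ccc(F)cc2)CC1` gives 41.3 mg/kg in this assay. Among the compounds with values here, of these two numbers, compound 1 has the lower one, and the gap to compound 2 lies beyond the scatter of repeated measurements; compound 2 differs from compound 1 in more than one place, so no single step is drawn between them.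

Compound 3 `O=c1oc2cccnc2n1CN1CCN(c2ccccc2)CC1` is not yet measured in this assay. It differs from compound 1 by hydrogen in place of trifluoromethyl on an aromatic carbon, on an aromatic carbon of a six-membered aromatic ring of carbon only, meta to a large group; the rest of the molecule is kept. Within the data shown here, no measured pair isolates this change, so the direction of the step rests on compound 1 alone.

The expectation is that compound 3 returns a somewhat higher number than compound 1, a step of a 2.2-fold higher number from compound 1 to compound 3 (0.35 log units; beyond the scatter). The estimate for compound 3 in this assay is 8 mg/kg, with a range from 3 mg/kg to 25 mg/kg.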

Compound 3, dose for half-maximal effect: 5.9 mg/kg
Compound 3: middle estimate off by 1.4-fold (0.13 log units), on the high side; low and high end bracket the measured number.
By their numbers in this assay, from the lowest: compounds 1 and 3 (each within the scatter of the next); then compound 2.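

Within the data shown here, replacing trifluoromethyl with hydrogen on an aromatic carbon, meta to a large group, gives a 1.6-fold higher number from compound 1 to compound 3 (0.21 log units; within the scatter) in this assay as the first single-place step. Removing these 4 heavy atoms therefore leaves no separation between the two compounds beyond the scatter, and trifluoromethyl is not required at this position for a number in the range of compound 1. No measurement at hand explains this result.

This single exchange gives no view of how other groups behave at the same aromatic carbon, and a methoxy group, a nitrile or an amine there could still move the number in either direction. Compound 2 differs from compound 1 in more than one place, so the contribution of its longer chain to the core, taken apart from its fluorine on the aromatic ring, remains unresolved.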